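The source may hold more compounds than are shown below. What is called first, only, known or untested is meant among the compounds shown, and "the series" means these compounds.

Working notes on the phenethylthiomethyl series in an ADME assay on HEL cells (Homo sapiens) for cytotoxicity, with a stated time of 3 days; on this read-out higher numbers stand for lower toxicity in this test and lower numbers for higher toxicity in this test.

Compound 1 `Cc1cc(-c2cccc([N+](=O)[O-])c2)c2ncc(CSCCc3ccccc3)n2c1` gives 100 ug/mL. Compound 2 `Cc1cc(-c2ccc(O)cc2)cn2c(CSCCc3ccccc3)cnc12` gives >= 100 ug/mL, a limit of the assay rather than a number. Compound 3 `COc1cccc(-c2cc(C)c3ncc(CSCCc4ccccc4)n3c2)c1` gives 20 ug/mL, the lowest of the two numbers, with compound 1 the nearest. The step of an at least 5.0-fold lower number from compound 2 to compound 3 (0.69 log units; beyond the scatter) starts from the limit (the limit of >= 100 ug/mL in this assay, at which 1 of the 3 values shown sits), so its true size is open.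

Compound 4 `COc1ccc(-c2cc(C)c3ncc(CSCCc4ccccc4)n3c2)cc1` differs from compound 3 by 4-methoxyphenyl in place of 3-methoxyphenyl on an aromatic carbon. Going by the values given here, the only measured step changes both the group and its position, so it bears weakly on a pure positional shift; no step beyond the scatter is expected. The expected step is a 1.5-fold higher number from compound 3 to compound 4 (0.18 log units; within the scatter). Compound 4 is expected at 30 ug/mL, within 10 ug/mL to 100 ug/mL.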

Compound 4, minimum cytotoxic concentration: 20 ug/mL
Beside the measured number, compound 4's estimate is 1.5-fold (0.18 log units) above it, within the range that was stated.
By their numbers in this assay, from the lowest: compounds 3 and 4 (each within the scatter of the next); then compound 1.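

In this assay, moving the methoxy group gives no change at the digits printed from compound 3 to compound 4 (within the scatter), so on this aromatic carbon the read-out does not separate 3-methoxyphenyl from 4-hydroxy-free 4-methoxyphenyl. Methyl in place of hydrogen on the oxygen gives an at least 5.0-fold lower number from compound 2 to compound 4 (0.69 log units; beyond the scatter), a change in one place only, unlike the earlier step to compound 3, which changed both group and position. The true size of that step stays open, as compound 2 sits at a limit of the assay: the limit of >= 100 ug/mL in this assay, at which 1 of the 4 values shown sits.

On these data alone, whether an amine or a longer alkoxy chain on this phenyl ring would move the read-out remains open. So does the effect of a free hydroxyl at the 3-position of the phenyl ring.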